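Replacing the benzyloxy cap of compound 2 with isopropyl

The compounds below may be only part of what the source reports. "The series", "measured", "known", "first", "only" and "open" are said of these compounds alone.

Of the compounds shown here, two have numbers so far. Compound 1 `CCCCCCC(O)[C@H](CC(C)C)NC(=O)[C@@H](NC(=O)[C@@H](NC(=O)CC)C(C)C)C(C)C` carries an ethyl group on the terminal carbonyl carbon; in an assay on isolated protein (plant) for inhibition of Pepsin A (Sus scrofa) (a higher number here means a weaker inhibitor, a lower number a stronger inhibitor), compound 1 gives 3200 nM. Compound 2 `CCCCCCC(O)[C@H](CC(C)C)NC(=O)[C@@H](NC(=O)[C@@H](NC(=O)OCc1ccccc1)C(C)C)C(C)C` carries benzyloxy in that place, and in this assay compound 2 gives 690 nM. For the measured compounds named here, the single step on record is a 4.6-fold lower number from compound 1 to compound 2 (0.67 log units; beyond the scatter). Compound 2 thus stands at the lowest of the two numbers, with compound 1 the nearest and higher.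

Compound 3 `CCCCCCC(O)[C@H](CC(C)C)NC(=O)[C@@H](NC(=O)[C@@H](NC(=O)C(C)C)C(C)C)C(C)C` differs from compound 2 in one place: isopropyl in place of benzyloxy on a carbonyl carbon. Going by the values given here, the only measured step that bears on this is a 4.6-fold lower number from compound 1 to compound 2 (0.67 log units; beyond the scatter), where benzyloxy entered for ethyl and the number fell. Isopropyl resembles the ethyl of compound 1 far more than the benzyloxy of compound 2, so much of that gain is expected to be given back, with an expected step of a 3.6-fold higher number from compound 2 to compound 3 (0.56 log units; beyond the scatter) back toward the number of compound 1. The estimate for compound 3 in this assay is 2500 nM, with a range from 900 nM to 7000 nM; the scatter of a single run leaves this uncertain.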

Compound 3, half-maximal inhibitory concentration: 3600 nM
The estimate for compound 3 lay 1.4-fold (0.16 log units) below the measured number, within the range that was stated.
By their numbers in this assay, from the lowest: compound 2; then compounds 1 and 3 (each within the scatter of the next).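

In this assay, removing benzyloxy from this carbonyl carbon in favour of isopropyl gives a 5.2-fold higher number from compound 2 to compound 3 (0.72 log units; beyond the scatter), so the difference seen earlier with ethyl also holds with a second, branched cap. The step of a 1.1-fold higher number from compound 1 to compound 3 (0.05 log units; within the scatter) adds that methyl in place of hydrogen on the saturated chain carbon does not separate the isopropyl and ethyl caps, which leaves compound 2 alone among the three compounds, with both of its steps to the others beyond the scatter. No measurement on record gives a reason for the separation between benzyloxy and the two smaller caps.

The change from benzyloxy to isopropyl removes a six-membered aromatic ring and an oxygen at once, along with several heavy atoms, so the three compounds cannot assign the difference to any one of these features. A benzyl group on the same carbonyl carbon would keep the ring without the oxygen and a tert-butoxy group would keep the oxygen without the ring, while a longer chain such as hexyl would test size alone.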